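A few compounds are considered here, and "the series" means these few. Any claim that something is new, unique, unknown or untested is made for them only; others in the source may bear on it.

In a functional assay for activation of Alpha-1B adrenergic receptor (Homo sapiens), read by calcium flux (a lower number here means that less compound is needed, a higher number that more compound is needed for the effect), two compounds have been measured so far. Compound 1, `c1csc(-c2ccccc2OCC2=NCCN2)c1`, gives 3.98 nM, and compound 2, `c1c[nH]c(-c2ccccc2OCC2=NCCN2)c1`, gives 1 nM. Within the data shown here, the one step between them, a 4.0-fold lower number from compound 1 to compound 2 (0.60 log units; beyond the scatter), is the only measured guide to how the five-membered ring attached to the shared core matters. Among the measured compounds shown here, compound 2 thus stands at the lower of the two numbers, with compound 1 the only neighbour.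

Compound 3, `c1ccc(-c2ccoc2)c(OCC2=NCCN2)c1`, is the next compound on this path. The change from compound 2 is furan-3-yl in place of 1H-pyrrol-2-yl on an aromatic carbon. For the measured compounds named here, no measured step covers this exact change; the one that bears on it is the thiophen-2-yl to 1H-pyrrol-2-yl step, a 4.0-fold lower number from compound 1 to compound 2 (0.60 log units; beyond the scatter), which shows that swapping one five-membered ring for another at this position moves the number by a modest but real amount. Since compound 3, like compound 1, carries no hydrogen-bond donor on that ring, the expectation is a step back toward or somewhat beyond the value of compound 1, estimated as a 6.0-fold higher number from compound 2 to compound 3 (0.78 log units; beyond the scatter). Compound 3 is therefore expected to give about 6 nM in this assay, with a likely range from 1.5 nM to 25 nM.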

Compound 3, half-maximal effective concentration: 5.01 nM
Compound 3: the middle estimate sits 1.2-fold (0.08 log units) above what was measured; the measured number falls inside the stated range.
By their numbers in this assay, from the lowest: compound 2; then compounds 1 and 3 (each within the scatter of the next).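

In this assay the step back up (a 5.0-fold higher number from compound 2 to compound 3 (0.70 log units; beyond the scatter)) shows that the low number of compound 2 is not shared by every five-membered aromatic ring on this aromatic carbon, ortho to a group of 7 heavy atoms. The furan-3-yl and thiophen-2-yl groups cannot be told apart here (a 1.3-fold higher number from compound 1 to compound 3 (0.10 log units; within the scatter)), although they differ both in the hetero atom and in the ring carbon through which they attach. This leaves 1H-pyrrol-2-yl alone at the lower number, and it is counted with 1 hydrogen-bond donor against 0 hydrogen-bond donors for furan-3-yl, an observation that rests on very few compounds.

From the compounds shown here alone, whether the pyrrole ring hydrogen is what matters remains open: a 1-methylpyrrol-2-yl group would address that directly, and 1H-pyrrol-3-yl or furan-2-yl would separate the point of attachment from the identity of the hetero atom. The compounds shown also say nothing about a plain phenyl ring or an aminomethyl group at this place. No measurement offered here explains why these groups give the numbers they do.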